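Swapping the Aryl Ether Group: Acid Dissociation Outlook

The source may hold more compounds than are shown below. What is called first, only, known or untested is meant among the compounds shown, and "the series" means these compounds.

Compound 1, `COc1cccc(CNCCCNc2ccnc3cc(C4CCCCC4)ccc23)c1O`: 9.47
Compound 2, `COc1cccc(Oc2ccc3c(NCCCNCc4cccc(OC)c4O)ccnc3c2)c1`: 9.28
Compound 3, `COc1cccc(CNCCCNc2ccnc3cc(Oc4cccc(N(C)C)c4)ccc23)c1O`: 9.28

These three compounds share one core and differ only in the group on one aromatic carbon. In a physicochemical assay for acid dissociation, compound 3 gives 9.28, level with compound 2 at the digits shown, and its gap to compound 1 is within the scatter: a number 0.19 log units lower from compound 1 to compound 3 (within the scatter). Compound 4, `COc1cccc(CNCCCNc2ccnc3cc(Oc4ccc(Cl)cc4)ccc23)c1O`, has not yet been measured. It arises from compound 3 by the change (4-chlorophenyl in place of 3-(dimethylamino)phenyl on an oxygen on an aromatic ring). Going by the values given here, two measured steps bear on this: no change at the digits printed from compound 2 to compound 3 (within the scatter) and a number 0.19 log units lower from compound 1 to compound 3 (within the scatter), neither beyond the scatter. A step of similar size, none beyond the scatter, is therefore expected: a number 0.02 log units higher from compound 3 to compound 4 (within the scatter). Compound 4 is accordingly estimated at 9.3, between 9 and 9.6.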

Compound 4, acid dissociation constant: 9.28
Estimate against measurement, compound 4: 0.02 log units above; measured number inside the range.
By their numbers in this assay, from the lowest: compounds 2, 3, 4 and 1 (each within the scatter of the next).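

In this assay, 4-chlorophenyl on the oxygen gives no change at the digits printed from compound 3 to compound 4 (within the scatter) against 3-(dimethylamino)phenyl and no change at the digits printed from compound 2 to compound 4 (within the scatter) against 3-methoxyphenyl, so a ring carrying chlorine joins the two earlier aryl ethers at the same printed number. Putting 4-chlorophenoxy in place of cyclohexyl gives a number 0.19 log units lower from compound 1 to compound 4 (within the scatter) and so keeps this swap inside the scatter as well. No measurement shown here offers an explanation for these results.

Still open, on these data alone, is whether a carboxylic acid on the phenoxy ring would also stay within the scatter. The same question stands for a longer alkyl chain at this place.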